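Hydroxyl for chloro in a cytotoxicity series

The source may hold more compounds than are shown below. What is called first, only, known or untested is meant among the compounds shown, and "the series" means these compounds.

Measured so far:
compound 1 `Clc1ccc(/C=N/c2sc3c(c2-c2nc4ccccc4s2)CCC3)cc1` 380 ug/mL
compound 2 `Clc1ccccc1/C=N/c1sc2c(c1-c1nc3ccccc3s1)CCC2` 138 ug/mL
compound 3 `Clc1ccc(/C=N/c2sc3c(c2-c2nc4ccccc4s2)CCCC3)cc1` 431 ug/mL

In an ADME assay on HeLa cells (Homo sapiens) for cytotoxicity, read by MTT assay, with a stated time of 72 h (a higher number here means that more compound is tolerated, a lower number that less compound is tolerated), compound 3 gives the highest of the three numbers; compound 1 sits within the scatter of it, while compound 2 is beyond it. Compound 4 `Oc1ccccc1/C=N/c1sc2c(c1-c1nc3ccccc3s1)CCCC2` differs from compound 3 by 2-hydroxyphenyl in place of 4-chlorophenyl on a carbon with a double bond to nitrogen. For the measured compounds named here, the only measured step, a 2.8-fold lower number from compound 1 to compound 2 (0.44 log units; beyond the scatter), changes the position of the chloro group, not its identity, so it bears on the change to compound 4 only loosely, and no step exchanging chloro for hydroxyl exists. Taking the modest drop of that step as the nearest guide, a downward step of similar size, a 1.5-fold lower number from compound 3 to compound 4 (0.19 log units; within the scatter), is expected for compound 4, with wide uncertainty. Compound 4 is estimated at 280 ug/mL, in the range 110 ug/mL to 700 ug/mL.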

Compound 4, half-maximal cytotoxic concentration: 122 ug/mL
Compound 4: middle estimate off by 2.3-fold (0.36 log units), on the high side; the range from low to high includes it.
By their numbers in this assay, from the lowest: compounds 4 and 2 (each within the scatter of the next); then compounds 1 and 3 (each within the scatter of the next).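

In this assay, replacing 4-chlorophenyl with 2-hydroxyphenyl on a carbon with a double bond to nitrogen lowers the number beyond the scatter (a 3.5-fold lower number from compound 3 to compound 4 (0.55 log units; beyond the scatter)). For the compounds shown here, until now only the place of the chloro group had varied (a 2.8-fold lower number from compound 1 to compound 2 (0.44 log units; beyond the scatter)), so this is the first sign that exchanging the group itself also moves the number. Group and place change together here, and no measurement on hand explains the step.

As far as these compounds go, how much of the step belongs to the hydroxyl and how much to its place remains open. Also open, from the compounds shown here alone, is how a methoxy group or an amine would compare on the same core.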